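The source may hold more compounds than are shown below. What is called first, only, known or untested is meant among the compounds shown, and "the series" means these compounds.

Three compounds sharing one core have been tested in an ADME assay on Vero cells (Chlorocebus sabaeus) for cytotoxicity; on this read-out higher numbers stand for lower toxicity in this test and lower numbers for higher toxicity in this test:

compound 1, `O=C(O)CCC(=O)Nc1ccc(-c2nc3cc(C(F)(F)F)ccc3[nH]2)cc1`, > 100000 nM
compound 2, `Fc1ccc(-c2nc3cc(C(F)(F)F)ccc3[nH]2)cc1`, 60000 nM
compound 3, `COc1cc(-c2nc3cc(C(F)(F)F)ccc3[nH]2)cc(OC)c1OC`, 29000 nM

Compound 1 stands at a limit of this assay, not at a measured number, namely (the limit of > 100000 nM in this assay, at which 1 of the 3 values shown sits). Compound 2 gives 60000 nM in this assay. Compound 3 gives 29000 nM in this assay, the lowest number among the three. Among the measured compounds shown here, the only step that can be read between measured compounds is an at least 1.6-fold lower number from compound 1 to compound 2 (0.22 log units; that floor lies within the scatter), and it is itself only a floor because compound 1 sits at the limit of > 100000 nM in this assay, at which 1 of the 3 values shown sits.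

Compound 4, `O=C(CN1CCCCC1)Nc1ccc(-c2nc3cc(C(F)(F)F)ccc3[nH]2)cc1`, differs from compound 1 by piperidin-1-yl in place of carboxymethyl on a saturated chain carbon bound to a carbonyl carbon. For the measured compounds named here, no measured pair shows this same change, so the step from compound 1 to compound 4 can only be framed loosely: the step from compound 1 to compound 2 was not larger than the scatter, and compound 3 shows that other changes on the attached ring reach a number somewhat lower than compound 2. The number for compound 4 is therefore expected to move from the limit of compound 1 by about an at least 1.6-fold lower number from compound 1 to compound 4 (0.22 log units; that floor lies within the scatter), downward, though a second limit cannot be ruled out. Compound 4 is estimated at 60000 nM, within a range from 20000 nM to 150000 nM in this assay.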

Compound 4, half-maximal cytotoxic concentration: 31000 nM
For compound 4 the middle estimate is 1.9-fold (0.29 log units) above the measured one, within the range that was stated.
By their numbers in this assay, from the lowest: compounds 3, 4 and 2 (each within the scatter of the next, the first and the last beyond it). At a limit, above all of these: compound 1.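

In this assay, piperidin-1-yl in place of carboxymethyl on a saturated chain carbon bound to a carbonyl carbon gives an at least 3.2-fold lower number from compound 1 to compound 4 (0.50 log units; beyond the scatter). This is the first change at this position that is shown to exceed the scatter, whereas the earlier change on the attached ring gave an at least 1.6-fold lower number from compound 1 to compound 2 (0.22 log units; that floor lies within the scatter). The true size of the new step remains unknown, since compound 1 stands at a limit: the limit of > 100000 nM in this assay, at which 1 of the 4 values shown sits.

The compounds shown leave open whether the step follows from the loss of the carboxylic acid or from the entry of the amine, and a compound carrying cyclohexyl in place of piperidin-1-yl, or an open-chain amine such as dimethylamino, would begin to separate the two. As far as these compounds go, it also remains open how a longer chain between the carbonyl and the piperidin-1-yl, or a ring with a second hetero atom such as morpholine, would change the number on this read-out.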